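The source may hold more compounds than are shown below. What is called first, only, known or untested is meant among the compounds shown, and "the series" means these compounds.

For the measured compounds named here, compound 3 `CC(=O)Nc1ccc(S(=O)(=O)Oc2ccccc2I)cc1` is tested in a functional assay on M21 cells (Homo sapiens) for antiproliferative activity, read by sulforhodamine B assay, with a stated time of 48 h (on this read-out lower numbers stand for stronger inhibition and higher numbers for weaker inhibition), where compound 3 gives 27000 nM, the highest of the three numbers known. Compound 2 `CC(=O)Nc1ccc(S(=O)(=O)Oc2ccccc2C(C)C)cc1` gives 21000 nM, and the step of a 1.3-fold higher number from compound 2 to compound 3 (0.11 log units; within the scatter) lies within the scatter. Compound 1 `CCCCCC(=O)Nc1cccc(S(=O)(=O)Oc2ccccc2C(C)C)c1` gives 11000 nM, a lower number beyond the scatter, but compound 1 differs from compound 3 in more than one place. Compound 4 `CC(C)(C)C(=O)Nc1ccc(S(=O)(=O)Oc2ccccc2I)cc1` differs from compound 3 by tert-butyl in place of methyl on a carbonyl carbon. Going by the values given here, no measured step changes this part alone, so nothing known bears on it directly. On that basis the step of a 1.2-fold lower number from compound 3 to compound 4 (0.09 log units; within the scatter) is expected to stay within the scatter. Compound 4 is therefore estimated at 22000 nM, with a range from 9000 nM to 55000 nM.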

Compound 4, half-maximal inhibitory concentration: 8300 nM
Compound 4: middle estimate off by 2.7-fold (0.42 log units), on the high side, outside the stated range (below it).
By their numbers in this assay, from the lowest: compounds 4, 1, 2 and 3 (each within the scatter of the next, the first and the last beyond it).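

In this assay, for the compounds shown here, tert-butyl in place of methyl on the carbonyl carbon gives a 3.3-fold lower number from compound 3 to compound 4 (0.51 log units; beyond the scatter), the first measured change at this place. The step lies beyond the scatter, so the group on this carbonyl carbon can alter the antiproliferative read-out, and here four heavy atoms in place of one go with the lower number. Nothing measured here explains the shift.

As far as these compounds go, whether a cyclopropyl group, a phenyl ring or an amine at this carbon would lower the number further remains open. So does whether tert-butyl gives a similar step when isopropyl replaces iodo.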